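Removing the Ring Fluorine from a Steroid Reductase Inhibitor

This account rests on a few compounds, and the source may have more. Where it says the series, first, only, none or still open, it means among the compounds named here.

Measured compounds:
Compound 1, `O=C(O)c1ccc(C=C2CCN(C(=O)C(c3ccccc3)c3ccccc3)CC2)c(F)c1`: 1100 nM
Compound 2, `O=C(O)c1ccc(C=C2CCN(C(=O)CC(c3ccccc3)c3ccccc3)CC2)cc1`: 1600 nM

Of the compounds shown here, two have been tested so far in an assay on Prostate gland for inhibition of 3-oxo-5-alpha-steroid 4-dehydrogenase 1 (Rattus norvegicus); a lower number here means a stronger inhibitor, a higher number a weaker inhibitor. Compound 1, `O=C(O)c1ccc(C=C2CCN(C(=O)C(c3ccccc3)c3ccccc3)CC2)c(F)c1`, gives 1100 nM in this assay. Compound 2, `O=C(O)c1ccc(C=C2CCN(C(=O)CC(c3ccccc3)c3ccccc3)CC2)cc1`, differs from it in two places at once and gives 1600 nM; the two numbers lie within the usual scatter of each other, so neither compound can be called the stronger inhibitor on these data.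

The new compound is compound 3, `O=C(O)c1ccc(C=C2CCN(C(=O)C(c3ccccc3)c3ccccc3)CC2)cc1`. Compared with compound 1 the change is hydrogen in place of fluoro on an aromatic carbon. Among the compounds with values here, no pair of measured compounds that differ only in this way exists, so the effect of this change has not been seen directly. Compound 2 already lacks the fluoro and still gives a number within the scatter of compound 1, which hints that the fluoro is not decisive here. The step from compound 1 to compound 3 is therefore expected to be a 1.4-fold higher number from compound 1 to compound 3 (0.13 log units; within the scatter), not beyond the scatter. Compound 3 is estimated at 1500 nM, with a range from 700 nM to 3500 nM.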

Compound 3, half-maximal inhibitory concentration: 3400 nM
For compound 3 the middle estimate is 2.3-fold (0.36 log units) below the measured one; the measured number falls inside the stated range.
By their numbers in this assay, from the lowest: compounds 1 and 2 (each within the scatter of the next); then compound 3.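

Read as a direct pair in this assay, the change from 4-carboxy-2-fluorophenyl to 4-carboxyphenyl brings a 3.1-fold higher number from compound 1 to compound 3 (0.49 log units; beyond the scatter), and this modest step is the first sign that the fluoro counts at this position. With the rest of the molecule held the same, the inhibitor with hydrogen on this aromatic carbon, ortho to a large group and meta to a carboxy group, is the weaker one, so a single fluorine atom is enough to move the result beyond the usual scatter. Compound 2 also lacks the fluoro, but it differs from compound 1 in a second place as well, so its number could not isolate this change the way the pair of compound 1 and compound 3 does.

No measurement at hand explains why the fluoro makes this difference. As far as these compounds go, it remains open whether chlorine or a methoxy group on the same carbon would match fluoro, and whether adding a fluoro to compound 2, with its longer chain, would produce a step of similar size.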